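From 4-methylphenyl to 3-methoxyphenyl on a shared core

A few compounds are considered here, and "the series" means these few. Any claim that something is new, unique, unknown or untested is made for them only; others in the source may bear on it.

In a functional assay on MCF7 cells (Homo sapiens) for antiproliferative activity, read by MTT assay, with a stated time of 72 h (on this read-out lower numbers stand for stronger inhibition and higher numbers for weaker inhibition), compound 1 `COc1cc(-n2ncnc2-c2ccc(C)cc2)cc(OC)c1OC` gives 540 nM. Going by the values given here, this is the only exact number available, so compound 1 is the single measured reference point. Compound 2 `COc1cc(-c2ncnn2-c2cccc(N)c2)cc(OC)c1OC` gives > 10000 nM, which is a limit of the assay and not a number. Compound 3 `COc1cc(-n2ncnc2-c2ccc(Cl)cc2)cc(OC)c1OC` gives > 10000 nM, which is also a limit. The evidence is therefore thin: the limit of > 10000 nM in this assay, at which 2 of the 3 values shown sit.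

Compound 4 `COc1cccc(-c2ncnn2-c2cc(OC)c(OC)c(OC)c2)c1` keeps the core of compound 1 and changes one group, with 3-methoxyphenyl in place of 4-methylphenyl on an aromatic carbon.

Among the compounds with values here, only one measured step bears on this change. Chloro in place of methyl on the 4-methylphenyl group gave an at least 18-fold higher number from compound 1 to compound 3 (1.26 log units; beyond the scatter), a large step beyond the scatter. Within the data shown here, compound 2 offers no measured single-place step from compound 1. Among the measured compounds shown here, with one large step as the only guide, a higher number is expected in this assay for the new group, although the size remains uncertain and the result could also reach the limit. The estimated change is a 5.6-fold higher number from compound 1 to compound 4 (0.74 log units; beyond the scatter). For compound 4 the expected value is 3000 nM, with an estimated range from 400 nM to 10000 nM.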

Compound 4, half-maximal inhibitory concentration: > 10000 nM
Compound 4 was reported as a limit; the forecaster's own chance of this, stated with the estimate: 40%; at least 3.3-fold (0.52 log units) between middle value and limit.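

In this assay, the earlier step changed only the small group on the 4-methylphenyl ring, whereas this one replaces that ring with 3-methoxyphenyl on the same aromatic carbon of the core, and it gives an at least 18-fold higher number from compound 1 to compound 4 (1.26 log units; beyond the scatter). For compound 4, > 10000 nM is a limit of the assay and not a number, so the step from compound 1 has a known minimum but no known full size. The step between compound 3 and compound 4 cannot be read, and 4-methylphenyl remains the only group at this position in the compounds shown with an exact value: the limit of > 10000 nM in this assay, at which 3 of the 4 values shown sit.

The compounds shown do not separate the effect of exchanging methyl for methoxy from the effect of placing a group at the 3-position of the phenyl ring, a question that 4-methoxyphenyl and 3-methylphenyl could help answer. As far as these compounds go, it also remains open whether a slightly larger 4-ethylphenyl group at this position would give a value that can be read, or would instead reach the limit.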